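This account rests on a few compounds, and the source may have more. Where it says the series, first, only, none or still open, it means among the compounds named here.

Measured so far in a functional assay on A-431 cells (Homo sapiens) for cytotoxicity; a lower number here means that less compound is needed, a higher number that more compound is needed for the effect:
- compound 1 `COC1=C(C)C(=O)/C(=C(O)/C=C/c2ccccc2OC)C(=O)C1(C)C`: 6.6 ug/mL
- compound 2 `COC1=C(C)C(=O)/C(=C(O)/C=C/c2ccccc2C)C(=O)C1(C)C`: 5.2 ug/mL

In this assay compound 2 gives 5.2 ug/mL, which lies within the scatter of compound 1, so the two compounds cannot be separated on these numbers. The next compound to be read is compound 3 `CCc1ccc(/C=C/C(O)=C2/C(=O)C(C)=C(OC)C(C)(C)C2=O)cc1`. The change is 4-ethylphenyl in place of 2-methylphenyl on a double-bonded chain carbon bound to a double-bonded chain carbon.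

Among the measured compounds shown here, only one measured step bears on this change: a 1.3-fold lower number from compound 1 to compound 2 (0.10 log units; within the scatter). That step exchanged methoxy for methyl on an aromatic carbon and stayed within the scatter. For the measured compounds named here, it is weak guidance, since no measured compound carries 4-ethylphenyl and the series holds only two numbers. No direction can be drawn from it, so no step beyond the scatter is expected in this assay. The expected step is a 1.1-fold higher number from compound 2 to compound 3 (0.02 log units; within the scatter), and the range is kept wide for lack of closer data. For compound 3 the estimated value is 5.5 ug/mL, with an expected range of 2.5 ug/mL to 12 ug/mL.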

Compound 3, concentration for half-maximal effect: 12 ug/mL
Estimate against measurement, compound 3: 2.2-fold (0.34 log units) below; measured number inside the range.
By their numbers in this assay, from the lowest: compounds 2, 1 and 3 (each within the scatter of the next, the first and the last beyond it).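

In this assay, among the compounds shown here, this aryl group on a double-bonded chain carbon bound to a double-bonded chain carbon now gives the first step beyond the scatter, though a modest one: 4-ethylphenyl in place of 2-methylphenyl gives (a 2.3-fold higher number from compound 2 to compound 3 (0.36 log units; beyond the scatter)). The same group in place of 2-methoxyphenyl stays within the scatter (a 1.8-fold higher number from compound 1 to compound 3 (0.26 log units; within the scatter)), so compound 3 separates only from compound 2, and the series shows a small, partial sensitivity to this exchange rather than a clear break from both earlier aryl groups. No measurement at hand accounts for this result.

The exchange alters both the alkyl group and its numbered place on the phenyl ring, so the compounds shown cannot tell which of the two matters; 4-methylphenyl and 2-ethylphenyl would separate them. It also remains open how this position responds to a group of a different kind, such as a 4-aminophenyl or a 4-carboxyphenyl, since all three aryl groups shown carry only a small alkyl or methoxy group.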